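A few compounds are considered here, and "the series" means these few. Any claim that something is new, unique, unknown or untested is made for them only; others in the source may bear on it.

Measured compounds:
- compound 1, `CS(=O)(=O)c1cc(C(=O)N=C(N)N)ccc1-n1ccnc1`: in a functional assay for inhibition of sodium/hydrogen exchanger (Oryctolagus cuniculus) (a higher number here means a weaker inhibitor, a lower number a stronger inhibitor), compound 1 gives 150 nM
- compound 2, `Cc1ccc(C(=O)N=C(N)N)cc1S(C)(=O)=O`: compound 2 gives 210 nM
- compound 3, `CS(=O)(=O)c1cc(C(=O)N=C(N)N)ccc1Cl`: compound 3 gives 380 nM

All three share one core and differ only in the group that sits on one aromatic carbon. Compound 3 carries the highest of the three numbers, but the steps to the other two differ in weight: a 1.8-fold higher number from compound 2 to compound 3 (0.26 log units; within the scatter), while a 2.5-fold higher number from compound 1 to compound 3 (0.40 log units; beyond the scatter). Only the latter counts as a real difference.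

Compound 4, `CS(=O)(=O)c1cc(C(=O)N=C(N)N)ccc1-n1ccc(=O)cc1`, is the next step from compound 3. The change is a group of 7 heavy atoms (5 carbon, 1 nitrogen, 1 oxygen; one six-membered aromatic ring with 1 hetero atom) in place of one chlorine atom, on an aromatic carbon. Within the data shown here, the step that bears most on it is the one from compound 1, where an aromatic ring with hetero atoms was replaced by chloro and the number rose beyond the scatter. Compound 4 reverses that kind of move, putting a ring back in place of the chloro. The step from compound 2 to compound 3 points the same way, only more weakly. On that basis a modest fall in the number is expected, a 1.9-fold lower number from compound 3 to compound 4 (0.28 log units; within the scatter), with the new ring behaving more like the ring of compound 1 than like chloro.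

The estimate for compound 4 in this assay is therefore 200 nM, with a range from 80 nM to 600 nM.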

Compound 4, half-maximal inhibitory concentration: 710 nM
Compound 4: middle estimate off by 3.6-fold (0.55 log units), on the low side, outside the stated range (above it).
By their numbers in this assay, from the lowest: compounds 1, 2, 3 and 4 (each within the scatter of the next, the first and the last beyond it).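

On this aromatic carbon, ortho to a methylsulfonyl group, having an aromatic ring there does not by itself keep the number low in this assay: replacing the five-membered ring with the six-membered ring that carries the oxygen gives a clear rise (a 4.7-fold higher number from compound 1 to compound 4 (0.68 log units; beyond the scatter)). The new ring also falls behind the much smaller methyl group (a 3.4-fold higher number from compound 2 to compound 4 (0.53 log units; beyond the scatter)), while it cannot be told apart from the single chlorine atom (a 1.9-fold higher number from compound 3 to compound 4 (0.27 log units; within the scatter)). So the identity of the ring matters here, not merely its presence, but nothing in the data explains the gap between the two rings.

The two rings differ in size, in their nitrogen count and in the oxygen, so the compounds shown cannot say which of these differences goes with the higher number. Also open, on these data alone, is how groups of a different kind would compare on this carbon, such as an amine, a methoxy group or a longer alkyl chain.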